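The source may hold more compounds than are shown below. What is called first, only, known or untested is meant among the compounds shown, and "the series" means these compounds.

Compound 1 `CC(C)C(=O)OC1CCC(CN2CCN(c3cc(=O)c4cc(C(F)(F)F)cc([N+](=O)[O-])c4s3)CC2)CC1` was tested in an ADME assay on Vero cells (Chlorocebus sabaeus) for cytotoxicity, read by MTT assay, with a stated time of 48 h; on this read-out higher numbers stand for weaker inhibition and lower numbers for stronger inhibition. In this assay compound 1 gives > 64 ug/mL, which is a limit of the assay rather than a number. Compound 2 `O=c1cc(N2CCN(CC3CCC(NS(=O)(=O)c4ccccc4)CC3)CC2)sc2c([N+](=O)[O-])cc(C(F)(F)F)cc12` carries (phenylsulfonyl)amino in place of (isopropylcarbonyl)oxy on a saturated ring carbon; in this assay compound 2 gives > 64 ug/mL, also a limit. Hence a step that the two limits leave unreadable from compound 1 to compound 2 has no readable size. Compound 3 `O=C(OC1CCC(CN2CCN(c3cc(=O)c4cc(C(F)(F)F)cc([N+](=O)[O-])c4s3)CC2)CC1)c1ccc(C(F)(F)F)cc1` differs from compound 1 by 4-(trifluoromethyl)phenyl in place of isopropyl on a carbonyl carbon. Because the limit of > 64 ug/mL in this assay, at which 2 of the 2 values shown sit, offers no readable step, no shift beyond the scatter is expected. Compound 3 is therefore estimated at 64 ug/mL, within 32 ug/mL to 128 ug/mL. The expected step in this assay is a number no higher from compound 1 to compound 3 (the limit leaves the size open).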

Compound 3, half-maximal inhibitory concentration: > 64 ug/mL
Compound 3 gave a limit, no number; the forecaster's own chance of this, stated with the estimate: 70%; the middle value lies on the limit itself.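

In this assay compound 3 gives > 64 ug/mL, a limit and not a number, so its step from compound 1 cannot be read. The compounds shown leave open where any of them would reach half-maximal inhibition, and whether the changed groups alter it.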